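The source may hold more compounds than are shown below. What is called first, only, known or untested is meant among the compounds shown, and "the series" means these compounds.

In a physicochemical assay for solubility, read by HPLC, in phosphate buffer, measured as kinetic solubility, at pH 7.4 (on this read-out higher numbers stand for higher solubility and lower numbers for lower solubility), compound 1 (`CCC(=O)c1cc(-c2ccc(Cl)cc2)n(-c2cccc(S(N)(=O)=O)c2)c1C`) gives 200 nM and compound 2 (`CCOC(=O)c1cc(-c2ccc(Cl)cc2)n(-c2ccc3cc[nH]c3c2)c1C`) gives 5100 nM while compound 3 (`CCC(=O)c1cc(-c2ccc(S(N)(=O)=O)cc2)n(-c2cccc(Cl)c2)n1`) gives 6900 nM on the same read-out. Compound 3 therefore stands level with compound 2 within the scatter, and its number lies well clear of that of compound 1, beyond the scatter. Compound 4 (`CCC(=O)c1cc(-c2ccc(S(N)(=O)=O)cc2)n(-c2ccc(Cl)cn2)n1`) has not yet been measured. Its difference from compound 3 (5-chloropyridin-2-yl in place of 3-chlorophenyl on an aromatic nitrogen) is 5-chloropyridin-2-yl in place of 3-chlorophenyl on an aromatic nitrogen, at the place next to the ring atom that bears a large group, and the rest of the structure is unchanged. Among the measured compounds shown here, no two measured compounds differ in one place only, so the data give no direct size for such a swap in this assay and the expectation starts from compound 3 at 6900 nM alone. A modest upward move is expected, one that may well stay within the scatter. The estimated step is a 1.4-fold higher number from compound 3 to compound 4 (0.14 log units; within the scatter) and it remains small. For compound 4 the estimated value is 9500 nM (3500 nM to 26000 nM as the expected range).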

Compound 4, solubility: 33700 nM
Estimate against measurement, compound 4: 3.5-fold (0.55 log units) below; measured number outside the range, above it.
By their numbers in this assay, from the lowest: compound 1; then compounds 2 and 3 (each within the scatter of the next); then compound 4.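

In this assay, among the compounds shown here, the single change on the aromatic nitrogen, 5-chloropyridin-2-yl in place of 3-chlorophenyl, gives a 4.9-fold higher number from compound 3 to compound 4 (0.69 log units; beyond the scatter), and this is the only pair here that differs in one place, so it is the only direct size available for any change. The two groups have the same heavy-atom count and both carry chlorine, yet one ring carbon exchanged for nitrogen, which adds one hydrogen-bond acceptor by count, comes with a chlorine numbered differently on the ring and a number that moves beyond the scatter, so this position on the aromatic nitrogen is one where a swap of this kind can shift the read-out. Nothing among the data presented accounts for why the number moved.

As far as these compounds go, the pair does not separate the ring nitrogen from the place of the chlorine, so it remains open whether an unsubstituted pyridin-2-yl, or a 3-chloropyridyl group that keeps the chlorine numbered as in compound 3, would move the number the same way. From the compounds shown here alone, how a methoxy group or a nitrile in place of the chlorine would read on this ring also remains open.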